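A few compounds are considered here, and "the series" means these few. Any claim that something is new, unique, unknown or untested is made for them only; others in the source may bear on it.

Compound 1 `COc1ccc(/C=C/C(=O)c2cccc(-c3ccc(F)cc3)c2)cc1` is one of three compounds of a shared core assessed in an assay on A549 cells for inhibition of transcription factor p65 (Homo sapiens), read by fluorescence, with a stated time of 2 h; on this read-out lower numbers stand for stronger inhibition and higher numbers for weaker inhibition. In this assay compound 1 gives only > 50000 nM, which is a limit of the assay rather than a measured number. Compound 2 `COc1ccc(/C=C/C(=O)c2ccc(N)c(-c3ccc(F)cc3)c2)cc1`, which carries an amino in place of a hydrogen on an aromatic carbon, likewise returns only the limit > 50000 nM in this assay. Compound 3 `O=C(/C=C/c1ccc(Br)cc1)c1cccc(-c2cccc(F)c2)c1` also stops at the limit > 50000 nM in this assay. The step that the two limits leave unreadable from compound 1 to compound 2 therefore cannot be read, because of the limit of > 50000 nM in this assay, at which 3 of the 3 values shown sit. No pair among these three compounds yields a readable step, so compound 1 stands nowhere on a scale of numbers; it sits at the same limit as the other two.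

Compound 4 `COc1ccc(/C=C/C(=O)c2cccc(Br)c2)cc1` differs from compound 1 by bromo in place of 4-fluorophenyl on an aromatic carbon. Within the data shown here, none of the measured steps bears on this change, and none of them has a readable size, so no direction of change beyond the scatter can be expected from the data. Compound 4 is thus estimated at 60000 nM, with a range from 15000 nM to 250000 nM. The step from compound 1 to compound 4 is accordingly expected to be a step that the limit leaves unreadable from compound 1 to compound 4, with the most likely outcome being that this assay again reports only a limit for compound 4.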

Compound 4, half-maximal inhibitory concentration: > 50000 nM
Compound 4 gave a limit, no number; the forecaster's own chance of this, stated with the estimate: 85%; the middle value lies beyond the limit too.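

The step from compound 1 to compound 4 cannot be read, because each of the two compounds gives only a limit of the assay and not a number: the limit of > 50000 nM in this assay, at which 4 of the 4 values shown sit. The compounds shown leave open how far any change on the shared core shifts the result in this assay, and what value a compound of this core would give.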